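The source may hold more compounds than are shown below. What is called first, only, known or untested is meant among the compounds shown, and "the series" means these compounds.

Measured in an assay for inhibition of 3-hydroxy-3-methylglutaryl-coenzyme A reductase (Rattus norvegicus); on this read-out lower numbers stand for stronger inhibition and higher numbers for weaker inhibition:

Compound 1, `Cc1cccc(-c2cc(Cl)cc(Cl)c2/C=C/[C@@H]2C[C@@H](O)CC(=O)O2)c1`: 16 nM
Compound 2, `Cc1cc(-c2cc(Cl)cc(Cl)c2/C=C/[C@@H]2C[C@@H](O)CC(=O)O2)ccc1F`: 29 nM
Compound 3, `Cc1cc(C)cc(-c2cc(Cl)cc(Cl)c2/C=C/[C@@H]2C[C@@H](O)CC(=O)O2)c1`: 13 nM

Of these three, compound 3 gives the lowest number in this assay, yet compound 1 stands so near that the step of a 1.2-fold lower number from compound 1 to compound 3 (0.09 log units; within the scatter) cannot be told from noise; only compound 2 lies further off, with a 2.2-fold lower number from compound 2 to compound 3 (0.35 log units; beyond the scatter) just past the scatter. The unmeasured compound 4, `O=C1C[C@H](O)C[C@@H](/C=C/c2c(Cl)cc(Cl)cc2-c2ccccc2)O1`, arises from compound 3 by phenyl in place of 3,5-dimethylphenyl on an aromatic carbon. Among the measured compounds shown here, the one measured step that speaks to this change is a 1.2-fold lower number from compound 1 to compound 3 (0.09 log units; within the scatter), where a methyl took the place of hydrogen on that same ring and the number barely moved. Compound 4 runs that change in reverse and goes one methyl further, so a small rise in the number, at most on the edge of the scatter, is the natural expectation; nothing here hints at a large shift. Compound 4 is therefore expected to give about 20 nM in this assay, within a range of 8 nM to 50 nM. That estimate means a step of a 1.5-fold higher number from compound 3 to compound 4 (0.19 log units; within the scatter), expected to stay close to the scatter.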

Compound 4, half-maximal inhibitory concentration: 80 nM
Compound 4: the middle estimate sits 4.0-fold (0.60 log units) below what was measured; the measured number lies above the stated range.
By their numbers in this assay, from the lowest: compounds 3, 1 and 2 (each within the scatter of the next, the first and the last beyond it); then compound 4.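

At this position the bare phenyl ring stands apart: in this assay, the single methyl lost in a 5.0-fold higher number from compound 1 to compound 4 (0.70 log units; beyond the scatter) counts for far more than the second methyl, whose step a 1.2-fold lower number from compound 1 to compound 3 (0.09 log units; within the scatter) stays within the scatter. The other two steps agree, with a 6.2-fold higher number from compound 3 to compound 4 (0.79 log units; beyond the scatter) and a 2.8-fold higher number from compound 2 to compound 4 (0.44 log units; beyond the scatter) both beyond the scatter, so compound 4 is the weakest of the four and none of the listed compounds goes against that. The effect of ring substitution is thus not additive across these compounds, since most of the difference appears with the first methyl.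

Nothing available explains why the loss of that methyl shifts the number so much. The compounds shown leave open whether a chloro, methoxy or ethyl group on the phenyl ring would restore the lower numbers as a methyl does.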